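Swapping Nitro for Dimethylamino at a Cytotoxicity Limit

The source may report more compounds than this note shows. Statements on the series, on what has been measured and on what is new or still open speak of the compounds shown alone.

In an ADME assay on CEMx174 cells (Homo sapiens) for cytotoxicity (a lower number here means that less compound is tolerated, a higher number that more compound is tolerated), compound 1 (`CC1=C(C(=O)OCC2CCCCC2)C(c2cccc(O)c2)NC(=O)N1C`) gives > 10000 nM as a limit of the assay and not a number. For compound 2 (`CC(C)C1=C(C(=O)OCC2CCCCC2)C(c2cccc(O)c2)NC(=O)N1`) the record reads "not determined" (no result reported) in this assay with no value to compare. Compound 3 (`CCC1=C(C(=O)OCC2CCCCC2)C(c2ccc([N+](=O)[O-])cc2)NC(=O)N1`) gives > 10000 nM as a limit too, so it stands at the limit of > 10000 nM in this assay, at which 2 of the 3 values shown sit, among these compounds.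

Compound 4 (`CCC1=C(C(=O)OCC2CCCCC2)C(c2ccc(N(C)C)cc2)NC(=O)N1`) carries dimethylamino in place of nitro on an aromatic carbon, para to a large group (dimethylamino in place of nitro on an aromatic carbon). Given the limit of compound 3 at > 10000 nM in this assay no change beyond the usual scatter is expected. The estimated step that the limit leaves unreadable from compound 3 to compound 4 is therefore small. Compound 4 is expected at 14000 nM with an estimated range from 5000 nM to 40000 nM in this assay once it is measured.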

Compound 4, half-maximal cytotoxic concentration: > 10000 nM
Compound 4 gave a limit, no number; the forecaster's own chance of this, stated with the estimate: 75%; the middle value lies beyond the limit too.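

Among these compounds, no step from compound 3 to compound 4 can be read, because both values are limits and not numbers: the limit of > 10000 nM in this assay, at which 3 of the 4 values shown sit. The compounds shown leave open whether dimethylamino in place of nitro changes anything in this assay.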